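Shortening the Linker Arm Toward the Shared Core

The source may hold more compounds than are shown below. What is called first, only, known or untested is meant among the compounds shown, and "the series" means these compounds.

In an assay on isolated protein for inhibition of hexokinase-1 (Rattus norvegicus), with a stated time of 6 h, tested at 10 mM (a higher number here means more inhibition at the concentration tested (going by the name of the read-out), a lower number less inhibition), compound 2 `O=C(CI)NCCCCCCC(=O)NCCCCCCNc1ncnc2c1ncn2[C@@H]1O[C@H](COP(=O)(O)OP(=O)(O)OP(=O)(O)O)[C@@H](O)[C@H]1O` gives 0%, level with compound 1 `O=C(CI)NCCCCC(=O)NCCCCCCNc1ncnc2c1ncn2[C@@H]1O[C@H](COP(=O)(O)OP(=O)(O)OP(=O)(O)O)[C@@H](O)[C@H]1O`, which gives 0% in this assay. Among the measured compounds shown here, the one measured step, no change at the digits printed from compound 1 to compound 2 (within the scatter), lengthened the chain and moved nothing. Compound 3 `O=C(CI)NCCC(=O)NCCCCCCNc1ncnc2c1ncn2[C@@H]1O[C@H](COP(=O)(O)OP(=O)(O)OP(=O)(O)O)[C@@H](O)[C@H]1O` goes the other way: ((iodomethyl)carbonyl)amino in place of 4-(((iodomethyl)carbonyl)amino)butyl on a saturated chain carbon, two bonds along the chain from a carbonyl carbon. For the measured compounds named here, only that lengthening step bears on this shortening, and it was flat, so compound 3 is expected to show a step of no change at the digits printed from compound 2 to compound 3 (within the scatter) in this assay, none beyond the scatter. Compound 3 is therefore estimated at 0%, with a range from 0% to 10%.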

Compound 3, a percentage reported as inhibition, at one concentration (the size of the read-out at that concentration, not a potency): 0%
The estimate for compound 3 equals the measured number at the digits printed; measured number inside the range.
By their numbers in this assay, from the lowest: compounds 1, 2 and 3 (each within the scatter of the next).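

In this assay, shortening the arm changes nothing: there is no change at the digits printed from compound 2 to compound 3 (within the scatter), and no change at the digits printed from compound 1 to compound 3 (within the scatter). The flat reading therefore holds in the shortening direction as well, and across all three chain lengths shown, compound 3 gives 0% with ((iodomethyl)carbonyl)amino two bonds along the chain from a carbonyl carbon. No supporting evidence bears on why these readings coincide. Still open, as far as these compounds go, is whether any arm on this shared core gives measurable inhibition, such as a longer chain than in compound 2, or a bromoacetamide or an amine in place of the iodoacetamide end.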